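The compounds below may be only part of what the source reports. "The series", "measured", "known", "first", "only" and "open" are said of these compounds alone.

Series of amides around the shared core of compound 1 `CC(C)N(Cc1cccc(OCCCCCC(=O)O)c1)C(=O)c1ccc(-c2cccc(OCc3ccccc3)c2)cc1`, tested in an ADME assay on HEK293 cells (Homo sapiens) for cytotoxicity, read by CellTiter-Glo and resazurin assay, with a stated time of 72 h; a lower number here means that less compound is needed, a higher number that more compound is needed for the effect. Compound 1 reaches only the assay limit, > 26000 nM. Compound 2 `COc1cccc(-c2ccc(C(=O)N(Cc3cccc(OCCCCCC(=O)O)c3)C(C)C)cc2)c1` likewise gives only a limit, > 20900 nM. Compound 3 `CCOC(=O)CCCCCOc1cccc(CN(C(=O)c2ccc(-c3cccc(OC)c3)cc2)C(C)C)c1` again gives only a limit, > 21000 nM. Both measured steps are therefore unreadable, a step that the two limits leave unreadable from compound 1 to compound 2 and a step that the two limits leave unreadable from compound 2 to compound 3, since the values sit at the limit of > 26000 nM in this assay, at which 1 of the 3 values shown sits, the limit of > 20900 nM in this assay, at which 1 of the 3 values shown sits, and (the limit of > 21000 nM in this assay, at which 1 of the 3 values shown sits). On the numbers shown compound 3 thus stands at a limit, as do the other two compounds, and no ordering among the three can be read from this assay.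

Compound 4 `CCOC(=O)CCCCCOc1cccc(CN(C(=O)c2ccc(-c3cccc(CC(=O)O)c3)cc2)C(C)C)c1` differs from compound 3 by carboxymethyl in place of methoxy on an aromatic carbon. Going by the values given here, no measured step bears directly on this change; the steps that exist, from compound 1 to compound 2 and from compound 2 to compound 3, are both unreadable and so give no size in either direction. Among the compounds with values here, the only guidance is that all three measured compounds sit at limits in this assay, so the expected step that the limit leaves unreadable from compound 3 to compound 4 is none beyond the scatter, with the outcome most probably again a limit. Compound 4 is accordingly estimated at 25000 nM in this assay, in the range 10000 nM to 60000 nM.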

Compound 4, half-maximal effective concentration: > 26000 nM
Compound 4 was reported as a limit; the forecaster's own chance of this, stated with the estimate: 85%; at least 1.0-fold (0.01 log units) between middle value and limit.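

Compound 4 gives only a limit, > 26000 nM. Compound 3 also gives only a limit, so the change from compound 3 to compound 4 yields no readable step in this assay. The compounds shown leave open whether any of them has a measurable half-maximal effective concentration, and how carboxymethyl and methoxy compare at this aromatic carbon.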